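A few compounds are considered here, and "the series" means these few. Any claim that something is new, unique, unknown or untested is made for them only; others in the source may bear on it.

Of the compounds shown here, three sharing one core have so far been measured in a functional assay on blood for antagonist activity at thromboxane A2 receptor (Homo sapiens); a lower number here means tighter binding, a higher number weaker binding. Compound 1 `CC(=O)NCc1ccccc1-c1ccc(COC2CC[C@H](N3CCCCCC3)[C@H]2OC/C=C\CCC(=O)O)cc1` gives 25.1 nM, compound 2 `NC(=O)Cc1ccccc1-c1ccc(COC2CC[C@H](N3CCCCCC3)[C@H]2OC/C=C\CCC(=O)O)cc1` gives 7.94 nM, and compound 3 `CS(=O)(=O)Nc1cccc(-c2ccc(COC3CC[C@H](N4CCCCCC4)[C@H]3OC/C=C\CCC(=O)O)cc2)c1` gives 12.6 nM. Compound 3 thus stands second highest of the three numbers; its nearest neighbour is compound 2 and its furthest is compound 1, and both of those gaps fall within the usual scatter of this assay. Among the compounds with values here, the only change beyond the scatter among the measured set is a 3.2-fold lower number from compound 1 to compound 2 (0.50 log units; beyond the scatter), a modest step.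

Compound 4 `O=C(O)CC/C=C\CO[C@H]1C(OCc2ccc(-c3ccccc3CO)cc2)CC[C@@H]1N1CCCCCC1` is not yet measured. It differs from compound 3 by 2-(hydroxymethyl)phenyl in place of 3-(methanesulfonamido)phenyl on an aromatic carbon. The measured steps that bear on such an exchange of the outer ring are a 2.0-fold lower number from compound 1 to compound 3 (0.30 log units; within the scatter) and a 1.6-fold higher number from compound 2 to compound 3 (0.20 log units; within the scatter), both within the scatter, which suggests that swapping this whole outer group has so far moved the number little. The entering group shares with the group of compound 1 the naming as a 2-substituted phenyl, and compound 1 sits within the scatter of compound 3.

Compound 4 is therefore expected to show no step beyond the scatter, namely a 1.6-fold higher number from compound 3 to compound 4 (0.20 log units; within the scatter). Compound 4 is estimated at 20 nM in this assay, within a range of 6 nM to 63 nM.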

Compound 4, dissociation constant: 3.16 nM
Beside the measured number, compound 4's estimate is 6.3-fold (0.80 log units) above it; the measured number lies below the stated range.
By their numbers in this assay, from the lowest: compound 4; then compounds 2, 3 and 1 (each within the scatter of the next, the first and the last beyond it).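

Swapping the outer ring of the core had not yet given a clear change from compound 3, but 2-(hydroxymethyl)phenyl in place of 3-(methanesulfonamido)phenyl in this assay gives a 4.0-fold lower number from compound 3 to compound 4 (0.60 log units; beyond the scatter) and so shows that this position can respond to the group placed there. The saturated chain carbon bound to the aromatic carbon now also has a clearer series: hydroxy in place of carbamoyl gives a 2.5-fold lower number from compound 2 to compound 4 (0.40 log units; beyond the scatter) and hydroxy in place of acetamido gives a 7.9-fold lower number from compound 1 to compound 4 (0.90 log units; beyond the scatter), which leaves compound 4 with the lowest number of the four, beyond the scatter from each of the others. No measurement shown explains why hydroxy goes with the lower number.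

The hydroxy group and its place on the outer ring are tied together here. 3-(hydroxymethyl)phenyl would be needed to separate the effect of the group from that of its position. An amine or a methoxy group on the same saturated chain carbon would show whether the lower number is particular to hydroxy.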